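Triazole Substituent Swap on a Weakly Active Lactone Scaffold

The compounds below may be only part of what the source reports. "The series", "measured", "known", "first", "only" and "open" are said of these compounds alone.

Measured so far:
compound 1 `O=C1O[C@H]([C@@H](O)Cn2cc(-c3cccc(O)c3)nn2)C(OCc2ccccc2)=C1OCc1ccccc1` — 54100 nM
compound 2 `COc1ccc(-c2cn(C/C=C3\OC(=O)C(OCc4ccccc4)=C3OCc3ccccc3)nn2)cc1` — > 100000 nM

Of the compounds shown here, two have been tested in a functional assay on CFPAC-1 cells (Homo sapiens) for antiproliferative activity, read by MTT assay, with a stated time of 72 h; on this read-out lower numbers stand for stronger inhibition and higher numbers for weaker inhibition. Compound 2 sits at the limit of > 100000 nM in this assay, at which 1 of the 2 values shown sits; its value of > 100000 nM is a limit of the assay and not a number. Among the measured compounds shown here, compound 1 is therefore the only compound with a measured number, giving 54100 nM in this assay, which already places it at weak inhibition.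

Compound 3 `O=C1O[C@H]([C@@H](O)Cn2cc(CNS(=O)(=O)c3ccc(Cl)cc3)nn2)C(OCc2ccccc2)=C1OCc1ccccc1` has not yet been measured. It differs from compound 1 in one place: (((4-chlorophenyl)sulfonyl)amino)methyl in place of 3-hydroxyphenyl on an aromatic carbon. For the measured compounds named here, no step between measured compounds is available to anchor this change, so the expectation rests on the weak starting point of compound 1 alone. A step from compound 1 to compound 3 that stays within the usual scatter, or drifts toward weaker inhibition, is expected, with a real chance that the assay returns only a limit. For compound 3 the expected step is a 1.2-fold higher number from compound 1 to compound 3 (0.08 log units; within the scatter). Compound 3 is estimated at 65000 nM in this assay, with a likely range from 20000 nM to 150000 nM.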

Compound 3, half-maximal inhibitory concentration: 38900 nM
For compound 3 the middle estimate is 1.7-fold (0.22 log units) above the measured one; the measured number falls inside the stated range.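

In this assay, replacing 3-hydroxyphenyl with (((4-chlorophenyl)sulfonyl)amino)methyl on the aromatic carbon of the five-membered aromatic ring with 3 nitrogen gives a 1.4-fold lower number from compound 1 to compound 3 (0.14 log units; within the scatter), so the two compounds cannot be told apart. This first comparison at this position shows that it takes a group of 12 heavy atoms in place of one of 7, with a sulfur, a nitrogen and a chlorine among them, and that the read-out still gives a measured number in the same weak range. Compound 2 remains a limit of the assay and not a number, and it is the only such limit among the compounds shown: the limit of > 100000 nM in this assay, at which 1 of the 3 values shown sits.

Going by these compounds, what an amine, a carboxylic acid or a plain phenyl on the same aromatic carbon would give stays open, as does whether the chlorine contributes anything to the value of compound 3. With a single step that lies within the scatter, the compounds shown also leave open whether any group at this position can move the number beyond the scatter.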